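Benzylthio-purine ribosides: moving to a 4-cyanophenyl sulfide

The source may report more compounds than this note shows. Statements on the series, on what has been measured and on what is new or still open speak of the compounds shown alone.

Measured compounds:
compound 1 `OC[C@H]1O[C@@H](n2cnc3c(CSc4ccccc4Cl)ncnc32)[C@H](O)[C@@H]1O` — 1780 nM
compound 2 `OC[C@H]1O[C@@H](n2cnc3c(CSc4ccccc4F)ncnc32)[C@H](O)[C@@H]1O` — 355 nM
compound 3 `OC[C@H]1O[C@@H](n2cnc3c(CSc4cccc(Cl)c4)ncnc32)[C@H](O)[C@@H]1O` — 282 nM

All three share the same ribosyl-purine core and differ only in the aryl group on the sulfur. In an assay on isolated protein for binding affinity to Equilibrative nucleoside transporter 1 (Homo sapiens) (on this read-out lower numbers stand for stronger inhibition and higher numbers for weaker inhibition), compound 3 gives the lowest of the three numbers; against compound 2 the gap is a 1.3-fold lower number from compound 2 to compound 3 (0.10 log units; within the scatter), so the two cannot be separated, while against compound 1 the gap is a 6.3-fold lower number from compound 1 to compound 3 (0.80 log units; beyond the scatter).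

Compound 4 `N#Cc1ccc(SCc2ncnc3c2ncn3[C@@H]2O[C@H](CO)[C@@H](O)[C@H]2O)cc1` is the next variation: 4-cyanophenyl in place of 3-chlorophenyl on a sulfur. Among the measured compounds shown here, none of the measured steps touches a nitrile or a 4-substituted phenyl, so no step bears directly on this change. What the series does show is that the aryl substituent matters: a 5.0-fold lower number from compound 1 to compound 2 (0.70 log units; beyond the scatter) and a 6.3-fold lower number from compound 1 to compound 3 (0.80 log units; beyond the scatter) are both beyond the scatter, whereas a 1.3-fold lower number from compound 2 to compound 3 (0.10 log units; within the scatter) is not. The change from compound 3 to compound 4 is therefore expected to shift this assay only modestly in either direction, most likely within the scatter, with a 1.1-fold higher number from compound 3 to compound 4 (0.03 log units; within the scatter) as the expected step. For compound 4 the estimate is 300 nM, with a range from 90 nM to 1000 nM.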

Compound 4, half-maximal inhibitory concentration: 81.3 nM
The estimate for compound 4 lay 3.7-fold (0.57 log units) above the measured number; measured number outside the range, below it.
By their numbers in this assay, from the lowest: compound 4; then compounds 3 and 2 (each within the scatter of the next); then compound 1.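

In this assay the aryl group on the sulfur can take the number clearly under the level shared by compound 2 and compound 3, which could not be separated from each other: 4-cyanophenyl in place of 3-chlorophenyl gives a step beyond the scatter (a 3.5-fold lower number from compound 3 to compound 4 (0.54 log units; beyond the scatter)), and 4-cyanophenyl in place of 2-fluorophenyl does the same (a 4.4-fold lower number from compound 2 to compound 4 (0.64 log units; beyond the scatter)). Against 2-chlorophenyl the same group gives the only large step in the series (a 22-fold lower number from compound 1 to compound 4 (1.34 log units; beyond the scatter)), so the aryl group on the sulfur spans a wider range than the first three compounds showed, and compound 4 now stands lowest of the four, with its steps to all three others beyond the scatter. No measurement at hand bears on what lies behind these steps.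

On these data alone, whether the gain belongs to the nitrile or to the 4-substituted phenyl stays open, and a 4-chlorophenyl or a 3-cyanophenyl on the sulfur would separate the two. Also open, as far as these compounds go, is how an amine or a carboxylic acid on the phenyl ring, or a longer chain on the sulfur, would read in this assay.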